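Fluorine Placement on a Phenoxy Group and Cell Growth

The compounds below may be only part of what the source reports. "The series", "measured", "known", "first", "only" and "open" are said of these compounds alone.

Measured compounds:
compound 1 `Cc1nn(C)c(Oc2ccccc2F)c1/C=N\CCCCCCOc1cc2oc(=O)cc(C)c2cc1Cl`: > 25000 nM
compound 2 `Cc1nn(C)c(Oc2cccc(F)c2)c1/C=N\CCCCCCOc1cc2oc(=O)cc(C)c2cc1Cl`: > 25000 nM
compound 3 `Cc1nn(C)c(Oc2ccc(F)cc2)c1/C=N\CCCCCCOc1cc2oc(=O)cc(C)c2cc1Cl`: 12500 nM

In a functional assay on HepG2 cells (Homo sapiens) for antiproliferative activity, read by MTT assay, with a stated time of 72 h (on this read-out higher numbers stand for weaker inhibition and lower numbers for stronger inhibition), compound 1 gives > 25000 nM, which is a limit of the assay and not a number. Compound 2 likewise gives > 25000 nM, again a limit. Within the data shown here, compound 3 gives 12500 nM, the only real number among the three; its neighbours sit at the limit of > 25000 nM in this assay, at which 2 of the 3 values shown sit. The step that the two limits leave unreadable from compound 1 to compound 2 cannot be read. The steps of an at least 2.0-fold lower number from compound 1 to compound 3 (0.30 log units; that floor lies within the scatter) and an at least 2.0-fold lower number from compound 2 to compound 3 (0.30 log units; that floor lies within the scatter) are floors, each still within the scatter, so compound 3 is not clearly better than the other two.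

Compound 4 `Cc1nn(C)c(Oc2cccc(F)c2F)c1/C=N\CCCCCCOc1cc2oc(=O)cc(C)c2cc1Cl` carries 2,3-difluorophenyl in place of 4-fluorophenyl on an oxygen on an aromatic ring. Among the measured compounds shown here, the 2,3-difluorophenyl group combines the fluorine places of compound 1 and compound 2, both of which reached only the limit, while no measured step tests a second fluorine. Compound 4 is therefore expected near 25000 nM, with a range from 8000 nM to 60000 nM. For compound 4 the expected step is a 2.0-fold higher number from compound 3 to compound 4 (0.30 log units; within the scatter), a rise in this assay that may again end at the limit.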

Compound 4, half-maximal inhibitory concentration: > 25000 nM
Compound 4: a limit, no number; the forecaster's own chance of this, stated with the estimate: 55%; the middle value lies on the limit itself.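

In this assay compound 4 gives > 25000 nM, which is a limit of the assay and not a number. Among these compounds, putting 2,3-difluorophenyl in place of 4-fluorophenyl on this oxygen yields no readable gain: the change gives an at least 2.0-fold higher number from compound 3 to compound 4 (0.30 log units; that floor lies within the scatter), so compound 3 remains the only compound with a real number. The steps to compound 4 from compound 1 and from compound 2, each adding one fluoro, cannot be read, and the set now crowds at one end of the scale: the limit of > 25000 nM in this assay, at which 3 of the 4 values shown sit.

Still open, on these data alone, is whether any other group at this place, such as a methoxyphenyl or a chlorophenyl, would clearly move the number away from that of compound 3. Also open, as far as these compounds go, is what a shorter chain or an added amine elsewhere in the shared structure would do.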